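Three measured compounds, one unmeasured: an ortho methylsulfonyl

A few compounds are considered here, and "the series" means these few. Any claim that something is new, unique, unknown or untested is made for them only; others in the source may bear on it.

The measured compounds, with their largest response in an assay on CHO cells with Alpha-2C adrenergic receptor (Homo sapiens) as the target; a lower number here means a smaller maximal response, a higher number a larger maximal response:
compound 1, `CC(Oc1ccccc1C=O)C1=NCCN1`, giving 0.6
compound 2, `CC(C)Oc1ccccc1OC(C)C1=NCCN1`, giving 0.7
compound 3, `CCc1ccccc1OC(C)C1=NCCN1`, giving 0.6

Compound 1 stands level with compound 3 at the digits printed, and the two of them share the lowest number of the three, though the step to compound 2, a number 0.10 higher from compound 1 to compound 2 (within the scatter), stays within the scatter, as does no change at the digits printed from compound 1 to compound 3 (within the scatter). The three numbers therefore cannot be told apart; whatever group sits on that aromatic carbon, the response stays close to the same fraction.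

Compound 4, `CC(Oc1ccccc1S(C)(=O)=O)C1=NCCN1`, is the compound not yet measured. Its change from compound 1 is methylsulfonyl in place of formyl on an aromatic carbon.

Among the measured compounds shown here, the steps that bear on it are the two that swap the same formyl for another group: a number 0.10 higher from compound 1 to compound 2 (within the scatter) and no change at the digits printed from compound 1 to compound 3 (within the scatter), both within the scatter. The step in the other direction, a number 0.10 lower from compound 2 to compound 3 (within the scatter), is likewise within the scatter. On that basis no step beyond the scatter is expected in this assay, in either direction, and the estimated step is no change at the digits printed from compound 1 to compound 4 (within the scatter).

For compound 4 the expected value in this assay is 0.6, with a range from 0.4 to 0.8.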

Compound 4, intrinsic activity: the largest response reached, as a fraction of the reference agonist's: 0.6
For compound 4 middle estimate and measured number coincide at the digits printed; the range from low to high includes it.
By their numbers in this assay, from the lowest: compounds 1, 3, 4 and 2 (each within the scatter of the next).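

In this assay, methylsulfonyl puts 4 heavy atoms on this aromatic carbon in place of the 2 of formyl, adds sulfur and brings 2 hydrogen-bond acceptors in place of 1, yet the result is no change at the digits printed from compound 1 to compound 4 (within the scatter). The comparisons with the other two groups agree, with no change at the digits printed from compound 3 to compound 4 (within the scatter) and a number 0.10 lower from compound 2 to compound 4 (within the scatter), so this sulfur-containing group joins formyl, ethyl and isopropoxy in a set of four compounds whose maximal responses cannot be told apart. Nothing available explains why the maximal response stays within the scatter across these groups.

As far as these compounds go, it remains open whether an amine, a carboxylic acid or a longer chain on this aromatic carbon would also stay within the scatter of these four compounds. The compounds shown also leave open how much of each compound is needed to reach its maximal response, a question that this read-out does not answer.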